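The compounds below may be only part of what the source reports. "The series", "measured", "known", "first", "only" and "open" are said of these compounds alone.

Values from an assay on isolated protein for inhibition of 2-Hydroxyacid oxidase 2 (Homo sapiens), tested at 10 uM; a higher number here means a stronger effect of the compound at the concentration tested, a lower number a weaker effect:
compound 1 `Cc1n[nH]c(C(=O)O)c1Cc1ccc(C(F)(F)F)cc1` gives 12%
compound 2 `Cc1n[nH]c(C(=O)O)c1Cc1cccc(-c2ccccc2F)c1` gives 22%
compound 3 `Cc1n[nH]c(C(=O)O)c1Cc1ccc(C#N)cc1` gives 6%

Compound 3 stands lowest of the three numbers; its nearest neighbour is compound 1, within the scatter, while compound 2 lies beyond the scatter above it. The next compound, compound 4 `Cc1n[nH]c(C(=O)O)c1Cc1ccc(-c2ccc(F)cc2)cc1`, differs from compound 3 in one place: 4-fluorophenyl in place of cyano on an aromatic carbon.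

For the measured compounds named here, only one measured step touches this position, a number 6 percentage points lower from compound 1 to compound 3 (within the scatter), and it is within the scatter; it exchanges two small groups, not a small group for a ring, so it says little about the present change. Going by the values given here, compound 2, the only measured compound that carries a fluorophenyl ring on the benzyl part, does so at a different place and with a different fluorophenyl, and no single-point step links it to compound 3. Compound 3 gives 6%, while compound 2 gives 22%, and that comparison is all that can be read. An upward step of a number 12 percentage points higher from compound 3 to compound 4 (beyond the scatter) is therefore expected, modest in size, and compound 4 is estimated at 18%, with a range from 5% to 35%.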

Compound 4, a percentage reported as inhibition, at one concentration (the size of the read-out at that concentration, not a potency): 25%
For compound 4 the middle estimate is 7 percentage points below the measured one; measured number inside the range.
By their numbers in this assay, from the lowest: compounds 3, 1, 2 and 4 (each within the scatter of the next, the first and the last beyond it).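

In this assay, for the compounds shown here, a ring at this place moves the read-out beyond the scatter (a number 19 percentage points higher from compound 3 to compound 4 (beyond the scatter)) and (a number 13 percentage points higher from compound 1 to compound 4 (beyond the scatter)), whereas the only earlier step here, an exchange of two small groups, stayed within it (a number 6 percentage points lower from compound 1 to compound 3 (within the scatter)). The 4-fluorophenyl group is therefore tolerated at this place and gives a modest gain over both cyano and trifluoromethyl. No measurement is available that explains this gain.

On these data alone, whether the gain belongs to the aromatic ring itself or to its fluorine stays open, and a plain phenyl or a 4-chlorophenyl group at this place would separate the two. Also open, as far as these compounds go, is how a saturated ring such as cyclohexyl, a morpholine or a longer alkyl chain would read here.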